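Compound 2 to compound 4: exchanging the amide side chain

A few compounds are considered here, and "the series" means these few. Any claim that something is new, unique, unknown or untested is made for them only; others in the source may bear on it.

Values in a physicochemical assay for solubility, read by LC-MS, in phosphate buffer, with a stated time of 24 h, at pH 7.4; on this read-out lower numbers stand for lower solubility and higher numbers for higher solubility
Compound 1 `O=C(Nc1ccccc1)c1cnc(NCc2c(F)ccc3c2CCO3)n2cnnc12` gives < 1000 nM (a limit)
Compound 2 `COCCC(=O)Nc1cnc(NCc2c(F)ccc3c2CCO3)n2cnnc12` gives 980000 nM
Compound 3 `CN(C)Cc1ccc(C(=O)Nc2cnc(NCc3c(F)ccc4c3CCO4)n3cnnc23)cc1` gives 520000 nM

Compound 2 stands with compound 3 at the top of the numbers shown, the two within the scatter of each other (a 1.9-fold lower number from compound 2 to compound 3 (0.28 log units; within the scatter)). The third value, for compound 1, is a limit (the limit of < 1000 nM in this assay, at which 1 of the 3 values shown sits).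

The change to compound 4 `CN(C(=O)c1ccccc1)c1cnc(NCc2c(F)ccc3c2CCO3)n2cnnc12` is benzoyl(methyl)amino in place of ((2-methoxyethyl)carbonyl)amino on an aromatic carbon. For the measured compounds named here, no measured compound carries this group, so two steps bear on it only in part. Compound 1 also has an aromatic ring of carbon only in its side group, and its step is large (an at least 980-fold higher number from compound 1 to compound 2 (2.99 log units; beyond the scatter)). Compound 3 has a carbonyl-linked aromatic ring, but with a 4-((dimethylamino)methyl) group that compound 4 lacks, and its step stays within the scatter (a 1.9-fold lower number from compound 2 to compound 3 (0.28 log units; within the scatter)).

A lower number is expected, short of the large step (a 25-fold lower number from compound 2 to compound 4 (1.39 log units; beyond the scatter)). The expected value for compound 4 is 40000 nM with an estimated range from 4000 nM to 300000 nM in this working estimate.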

Compound 4, solubility: 280000 nM
Compound 4: middle estimate off by 7.0-fold (0.85 log units), on the low side; measured number inside the range.
By their numbers in this assay, from the lowest: compounds 4, 3 and 2 (each within the scatter of the next, the first and the last beyond it). At a limit, below all of these: compound 1.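

Putting benzoyl(methyl)amino on this aromatic carbon, with its six-membered aromatic ring of carbon only and 0 hydrogen-bond donors, keeps the number high in this assay, with only a modest step: a 3.5-fold lower number from compound 2 to compound 4 (0.54 log units; beyond the scatter). Compound 1 also carries an aromatic ring of carbon only in its side group, yet the step to the new compound is large, an at least 280-fold higher number from compound 1 to compound 4 (2.44 log units; beyond the scatter), so in these compounds such a ring does not by itself bring the number down to the level of compound 1. The number for compound 1 is a limit: the limit of < 1000 nM in this assay, at which 1 of the 4 values shown sits.

The compounds shown do not separate the methyl on the amide nitrogen from the order of carbonyl and nitrogen in the link, which a plain benzoylamino group would help to settle. From the compounds shown here alone, how an amine or a carboxylic acid on the benzoyl ring would read at this position also remains open.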